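From Hydroxymethyl to Carboxy on the Shared Core

This account rests on a few compounds, and the source may have more. Where it says the series, first, only, none or still open, it means among the compounds named here.

In a functional assay on HepG2 cells (Homo sapiens) for cytotoxicity, read by WST assay, with a stated time of 24 h (on this read-out higher numbers stand for lower toxicity in this test and lower numbers for higher toxicity in this test), compound 3 `Cc1cc(-c2ccc3cc(CO)ccc3c2)ccc1O` gives only a limit, > 32 ug/mL, and no number. Compound 4 `Cc1cc(-c2ccc3cc(C(=O)O)ccc3c2)ccc1O` differs from it in one place: carboxy in place of hydroxymethyl on an aromatic carbon. This puts carboxy in place of hydroxymethyl on an aromatic carbon. Carboxy is already present in compound 1 `CCCCCC=Cc1cc(-c2ccc3cc(C(=O)O)ccc3c2)ccc1O`, which gives 2.44 ug/mL, and in compound 2 `CCCCCCCc1cc(-c2ccc3cc(C(=O)O)ccc3c2)ccc1O`, which gives 1.89 ug/mL. Both, however, carry a longer chain than compound 4, namely hept-1-en-1-yl and heptyl. Among the compounds with values here, the only measured step, a 1.3-fold lower number from compound 1 to compound 2 (0.11 log units; within the scatter), lies within the scatter and concerns that chain, so it does not size the present change. Compound 2 at 1.89 ug/mL shows that a carboxy compound can sit at low numbers, but compound 4 lacks its heptyl, so only a moderate move toward lower numbers is expected. The expected change is an at least 1.6-fold lower number from compound 3 to compound 4 (0.20 log units; that floor lies within the scatter), an uncertain estimate that starts from a limit. For compound 4 the estimated value is 20 ug/mL, with an expected range of 7 ug/mL to 45 ug/mL.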

Compound 4, concentration lethal to 50% of the cells: > 32 ug/mL
Compound 4: only a limit was reported; the forecaster's own chance of this, stated with the estimate: 40%; at least 1.6-fold (0.20 log units) between middle value and limit.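

In this assay compound 4, like compound 3, gives a limit and not a number, and the step between them cannot be read: the limit of > 32 ug/mL in this assay, at which 2 of the 4 values shown sit.

Within the data shown here, what the earlier compounds did not show is that carboxy on the shared core does not by itself go with low numbers. Hydrogen in place of hexyl on a saturated chain carbon bound to an aromatic carbon gives an at least 16-fold higher number from compound 2 to compound 4 (1.22 log units; beyond the scatter), and the change from hept-1-en-1-yl to methyl gives an at least 13-fold higher number from compound 1 to compound 4 (1.11 log units; beyond the scatter).

The compounds shown leave open whether a heptyl chain would give low numbers with hydroxymethyl in place of carboxy, which would tell whether the chain depends on carboxy at all. From the compounds shown here alone, how a shorter chain such as propyl or pentyl would read, or an amine in place of carboxy, also stays open.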